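The source may report more compounds than this note shows. Statements on the series, on what has been measured and on what is new or still open speak of the compounds shown alone.

In a functional assay on DU-145 cells (Homo sapiens) for cytotoxicity, read by MTT assay (on this read-out higher numbers stand for weaker inhibition and lower numbers for stronger inhibition), compound 1 `CC(C)=CC[C@@H](OC(=O)c1ccco1)C1=CC(=O)c2c(O)ccc(O)c2C1=O` reports only a limit, > 100000 nM. Compound 2 `CCC(O)CO[C@H](CC=C(C)C)C1=CC(=O)c2c(O)ccc(O)c2C1=O` gives 16400 nM and compound 3 `CC(C)=CC[C@@H](OC(=O)C1CCCO1)C1=CC(=O)c2c(O)ccc(O)c2C1=O` gives 10500 nM. Within the data shown here, these are the only two true numbers so far, and they lie within the scatter of each other: a 1.6-fold lower number from compound 2 to compound 3 (0.19 log units; within the scatter). Both differ clearly from the first compound: an at least 6.0-fold lower number from compound 1 to compound 2 (0.78 log units; beyond the scatter) and an at least 9.5-fold lower number from compound 1 to compound 3 (0.97 log units; beyond the scatter).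

Compound 4 `CCC(CO[C@H](CC=C(C)C)C1=CC(=O)c2c(O)ccc(O)c2C1=O)OC` is the next to be read, and it differs from compound 3 as follows: 2-methoxybutyl in place of (oxolan-2-yl)carbonyl on an oxygen on a saturated carbon. Thus 2-methoxybutyl enters in place of (oxolan-2-yl)carbonyl on an oxygen on a saturated carbon. Among the measured compounds shown here, the closest precedent is the exchange of 2-hydroxybutyl and (oxolan-2-yl)carbonyl, a 1.6-fold lower number from compound 2 to compound 3 (0.19 log units; within the scatter), which stayed within the scatter. The larger steps both start from a limit and involve the furan-2-yl group, which compound 4 lacks, so they bear on this change only weakly. No step beyond the scatter is therefore expected in this assay, and the direction is left open.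

The expected step is a 1.3-fold higher number from compound 3 to compound 4 (0.12 log units; within the scatter). For compound 4 the estimated value is 14000 nM, with an expected range of 5500 nM to 36000 nM.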

Compound 4, half-maximal inhibitory concentration: 45700 nM
Compound 4: middle estimate off by 3.3-fold (0.51 log units), on the low side; the measured number lies above the stated range.
By their numbers in this assay, from the lowest: compounds 3 and 2 (each within the scatter of the next); then compound 4. At a limit, above all of these: compound 1.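

In this assay, methyl in place of hydrogen on an oxygen on a saturated carbon gives a 2.8-fold higher number from compound 2 to compound 4 (0.45 log units; beyond the scatter), so even this small change within the side chain moves the number beyond the scatter. The exchange of (oxolan-2-yl)carbonyl for 2-methoxybutyl gives a 4.4-fold higher number from compound 3 to compound 4 (0.64 log units; beyond the scatter), which shows that this position does not treat every replacement alike, although compounds 2 and 3 lie within the scatter of each other. The remaining step, an at least 2.1-fold lower number from compound 1 to compound 4 (0.34 log units; beyond the scatter), still sets the furan-2-yl ester apart, but it rests on a limit and gives only a bound: the limit of > 100000 nM in this assay, at which 1 of the 4 values shown sits.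

The compounds shown leave open whether an amine or a longer chain on this oxygen would bring the number back towards that of compound 2. They also leave open whether the methyl effect would hold in another cell line.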